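Exchanging a Hydroxyalkyl Tail for a Dimethylamino Group

The source may hold more compounds than are shown below. What is called first, only, known or untested is meant among the compounds shown, and "the series" means these compounds.

The two measured compounds and their values:
- compound 1, `CNC1=Nc2ccc(Cl)cc2C(C)(C)C1`: 92.3%
- compound 2, `CC1(C)CC(NCCCCO)=Nc2ccc(Cl)cc21`: 84.9%

In a functional assay on MDA-MB-231 cells (Homo sapiens) for cytotoxicity, read by MTT assay, with a stated time of 72 h, tested at 5 uM, in the absence of a further agent (on this read-out lower numbers stand for a stronger effect and higher numbers for a weaker effect at the one concentration tested), compound 1 gives 92.3% and compound 2 gives 84.9%. Going by the values given here, compound 2 is the lower of the two numbers, but its only neighbour is compound 1, and the step of a number 7.4 percentage points lower from compound 1 to compound 2 (within the scatter) is within the scatter, so the two compounds cannot be ordered on these readings.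

The unmeasured compound 3, `CN(C)CCNC1=Nc2ccc(Cl)cc2C(C)(C)C1`, differs from compound 2 by dimethylamino in place of 2-hydroxyethyl on a saturated chain carbon, two bonds along the chain from an amine nitrogen. Among the compounds with values here, no measured step changes the chain in this way; the one step that is known, a number 7.4 percentage points lower from compound 1 to compound 2 (within the scatter), concerns the whole 3-hydroxypropyl group and was within the scatter. With nothing bearing directly on the exchange, no movement beyond the scatter is expected in this assay, so compound 3 is expected near compound 2, the expected step being a number 0.1 percentage points higher from compound 2 to compound 3 (within the scatter). Compound 3 is therefore estimated at 85%, with a range from 70% to 98%.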

Compound 3, a percentage reported as activity, at one concentration (the size of the read-out at that concentration, not a potency): 50.8%
The estimate for compound 3 lay 34.2 percentage points above the measured number, and the stated range ends above it.
By their numbers in this assay, from the lowest: compound 3; then compounds 2 and 1 (each within the scatter of the next).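

In this assay this position proves responsive: dimethylamino in place of 2-hydroxyethyl, on a saturated chain carbon, two bonds along the chain from an amine nitrogen, gives a number 34.1 percentage points lower from compound 2 to compound 3 (beyond the scatter) and is the first change among these compounds to leave the scatter. Measured against compound 1, the complete side chain gives a number 41.5 percentage points lower from compound 1 to compound 3 (beyond the scatter), whereas the hydroxyalkyl chain of compound 2 had stayed within the scatter of compound 1, so adding a chain at this nitrogen does not by itself move the number, and the end of the chain matters here. The exchanged groups both count 3 heavy atoms, with nitrogen in place of oxygen and no hydrogen-bond donor in place of one, but nothing available explains why the number moves.

The compounds shown leave open whether a primary amine, a diethylamino group or a carboxylic acid at the same place would behave like dimethylamino, and whether a longer chain carrying the dimethylamino group would keep the step. They also leave open how the effect depends on concentration, since each number is a reading at one concentration and not a potency.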